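The source may report more compounds than this note shows. Statements on the series, on what has been measured and on what is new or still open speak of the compounds shown alone.

Working notes on the series

Compound 1 `OC1CC2(N3CCCC3)CC(c3ccccc3)C1C(c1ccccc1)C2` carries pyrrolidin-1-yl on the shared core, and in an ADME assay on L6 cells (Rattus norvegicus) for cytotoxicity (on this read-out higher numbers stand for weaker inhibition and lower numbers for stronger inhibition), compound 1 gives 26800 nM. Compound 2 `OC1CC2(N3CCCCC3)CC(c3ccccc3)C1C(c1ccccc1)C2` is its piperidin-1-yl counterpart; in this assay compound 2 gives 37300 nM. The change between them is piperidin-1-yl in place of pyrrolidin-1-yl on a saturated ring carbon, and the step it made was a 1.4-fold higher number from compound 1 to compound 2 (0.14 log units; within the scatter), so on this pair the ring enlargement left the read-out essentially where it was.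

Compound 3 `OC1CC2(N3CCCC3)CC(c3ccc(Cl)cc3)C1C(c1ccc(Cl)cc1)C2` is the pyrrolidin-1-yl member of a second core; how this core differs from that of compound 1 is not broken down here. In this assay compound 3 gives 3590 nM, the lowest number of the three measured and beyond the scatter from both compound 1 and compound 2, so compound 3 is the strongest inhibitor measured so far.

Compound 4 `OC1CC2(N3CCCCC3)CC(c3ccc(Cl)cc3)C1C(c1ccc(Cl)cc1)C2` has not yet been measured. It differs from compound 3 by piperidin-1-yl in place of pyrrolidin-1-yl on a saturated ring carbon. This is the same kind of change as that from compound 1 to compound 2, though the surroundings differ: in compound 3 the ring atom two bonds away bears a 4-chlorophenyl group, where in compound 1 it bears a phenyl group. Going by the values given here, only one measured instance of this change exists, so the expectation rests on a single pair.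

For compound 4 the step is expected to be small, a 1.4-fold higher number from compound 3 to compound 4 (0.14 log units; within the scatter), because the same change gave a 1.4-fold higher number from compound 1 to compound 2 (0.14 log units; within the scatter). In this assay compound 4 is therefore expected to give about 5000 nM, estimated to fall between 2500 nM and 10000 nM.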

Compound 4, half-maximal inhibitory concentration: 11600 nM
For compound 4 the middle estimate is 2.3-fold (0.37 log units) below the measured one, outside the stated range (above it).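

In this assay, piperidin-1-yl in place of pyrrolidin-1-yl on the core of compound 3 gives a 3.2-fold higher number from compound 3 to compound 4 (0.51 log units; beyond the scatter). Set beside the same change on the core of compound 1, the two steps cannot be told apart: the same change on two cores in this assay, a 1.4-fold higher number (0.14 log units; within the scatter) from compound 1 to compound 2 and a 3.2-fold higher number (0.51 log units; beyond the scatter) from compound 3 to compound 4, 2.3-fold (0.37 log units) apart, within the scatter of two such steps The change therefore carries between these two cores with no measurable difference in step size, but two pairs are too few to fix a size for it or to rule out some dependence on the core.

The compounds shown carry only pyrrolidin-1-yl and piperidin-1-yl on this saturated ring carbon, so it remains open how an open-chain amine such as dimethylamino, or a ring with a second hetero atom such as morpholin-4-yl, would read in this assay on either core. Also open, going by these compounds, is whether the step would hold with aryl groups other than phenyl and 4-chlorophenyl, such as 4-methoxyphenyl, or with a carbonyl in place of the hydroxy group.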